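A Secondary Amide Bearing a Methoxymethyl Benzyl Group

This account rests on a few compounds, and the source may have more. Where it says the series, first, only, none or still open, it means among the compounds named here.

Going by the values given here, compound 1 `CCN(Cc1ccccc1)C(=O)c1nn(-c2ccc(F)cc2)c(OC[C@@H](O)C[C@@H](O)CC(=O)O)c1C(C)C` is one of three compounds measured in an assay on microsomes from liver for inhibition of 3-hydroxy-3-methylglutaryl-coenzyme A reductase (Rattus norvegicus) (on this read-out higher numbers stand for weaker inhibition and lower numbers for stronger inhibition), where compound 1 gives 14 nM. Compound 2 `CC(C)c1c(C(=O)N(C)Cc2ccccc2)nn(-c2ccc(F)cc2)c1OC[C@@H](O)C[C@@H](O)CC(=O)O` gives 5.2 nM, and compound 3 `Cc1ccc(CNC(=O)c2nn(-c3ccc(F)cc3)c(OC[C@@H](O)C[C@@H](O)CC(=O)O)c2C(C)C)cc1` gives 15 nM. Among these three numbers compound 1 stands second highest; its nearest neighbour is compound 3 and its furthest is compound 2, with a 2.7-fold lower number from compound 1 to compound 2 (0.43 log units; beyond the scatter). Compound 1 and compound 3 are joined by a 1.1-fold higher number from compound 1 to compound 3 (0.03 log units; within the scatter), while compound 2 and compound 3 are joined by a 2.9-fold higher number from compound 2 to compound 3 (0.46 log units; beyond the scatter).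

Compound 4 `COCc1cccc(CNC(=O)c2nn(-c3ccc(F)cc3)c(OC[C@@H](O)C[C@@H](O)CC(=O)O)c2C(C)C)c1` differs from compound 1 in one place: (3-(methoxymethyl)benzyl)amino in place of benzyl(ethyl)amino on a carbonyl carbon. The step that bears most directly on this change is a 1.1-fold higher number from compound 1 to compound 3 (0.03 log units; within the scatter), in which the benzyl(ethyl)amino group was likewise replaced by a substituted benzylamino group and the number did not move beyond the scatter. The step of a 2.9-fold higher number from compound 2 to compound 3 (0.46 log units; beyond the scatter) shows only that such a secondary amide sits higher than compound 2. Compound 4 is therefore expected to show no step beyond the scatter, a 1.1-fold higher number from compound 1 to compound 4 (0.03 log units; within the scatter). The estimate for compound 4 in this assay is 15 nM, with a range from 7 nM to 32 nM.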

Compound 4, half-maximal inhibitory concentration: 31 nM
Compound 4: middle estimate off by 2.1-fold (0.32 log units), on the low side; low and high end bracket the measured number.
By their numbers in this assay, from the lowest: compound 2; then compounds 1 and 3 (each within the scatter of the next); then compound 4.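

In this assay, a substituted benzylamino group at this carbonyl carbon does not always stay level with compound 1: the (3-(methoxymethyl)benzyl)amino group gives a 2.2-fold higher number from compound 1 to compound 4 (0.35 log units; beyond the scatter), whereas compound 3 stayed within the scatter. With the amide hydrogen kept, 3-(methoxymethyl)phenyl in place of 4-methylphenyl gives a 2.1-fold higher number from compound 3 to compound 4 (0.32 log units; beyond the scatter), so the loss of the amide's ethyl group alone does not account for the rise. The gap to the benzyl(methyl)amino amide also widens to a 6.0-fold higher number from compound 2 to compound 4 (0.78 log units; beyond the scatter), the largest step among these compounds. No measurement on hand gives a reason for these steps.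

The compounds shown leave open whether the rise belongs to the methoxymethyl group itself or to its place on the ring. They also do not show how a hydroxymethyl or a dimethylaminomethyl group would behave there.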